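Oral exposure after opening the cyclopropyl ring: compound 3

The compounds below may be only part of what the source reports. "The series", "measured", "known", "first", "only" and "open" are said of these compounds alone.

In an in vivo ADME assay on the whole organism (strain Sprague-Dawley) for pharmacokinetics, with Rattus norvegicus as the target, at a dose of 2 mg/kg by the oral route (a lower number here means that a smaller share of the oral dose reaches the circulation, a higher number that a larger share of the oral dose reaches the circulation), compound 1 (`Cc1cc(CCC(=O)O)ccc1-c1noc(-c2ccc(OC(C)C)c(C#N)c2)n1`) gives 53% and compound 2 (`Cc1cc([C@@H]2C[C@H]2C(=O)O)ccc1-c1noc(-c2ccc(OC(C)C)c(C(F)(F)F)c2)n1`) gives 88% as the highest of the two numbers, a gap beyond the scatter. Compound 3 (`Cc1cc(C(C)CC(=O)O)ccc1-c1noc(-c2ccc(OC(C)C)c(C(F)(F)F)c2)n1`) carries 1-(carboxymethyl)ethyl in place of 2-carboxycyclopropyl on an aromatic carbon. Going by the values given here, no measured pair differs in one place, so this expectation rests on little. A downward step in this assay is expected, likely beyond the scatter, with the estimated change being (a number 20 percentage points lower from compound 2 to compound 3 (beyond the scatter)). For compound 3 the estimated value is 68% within an expected range (45% to 90%).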

Compound 3, oral bioavailability: 100%
Estimate against measurement, compound 3: 32 percentage points below, and the stated range ends below it.
By their numbers in this assay, from the lowest: compound 1; then compound 2; then compound 3.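

In this assay, the step on this aromatic carbon, para to a large group, is a number 12 percentage points higher from compound 2 to compound 3 (beyond the scatter) on replacing 2-carboxycyclopropyl with 1-(carboxymethyl)ethyl. Oral exposure in this pair therefore does not depend on the three-membered ring, and the open chain with no ring stands at the higher number. No measurement on hand bears on what lies behind this step. Open, on these data alone, is whether a longer chain ending in the carboxylic acid, or a primary amide in its place, holds this exposure. Also open, as far as these compounds go, is whether the same change carries over with nitrile in place of trifluoromethyl.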